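Aryl Swap on a Triazole Nitrogen with All Values at the Limit

The compounds below may be only part of what the source reports. "The series", "measured", "known", "first", "only" and "open" are said of these compounds alone.

Three compounds share one core and differ only in the aryl group on an aromatic nitrogen. Compound 1 `CC(C)n1ncc2c(C(=O)NCc3cn(-c4ccc(I)cc4)nn3)cccc21` carries a 4-iodophenyl there. In a functional assay on MCF7 cells (Homo sapiens) for inhibition, read by MTT assay, with a stated time of 72 h (a lower number here means a stronger inhibitor, a higher number a weaker inhibitor), compound 1 is reported only as a limit, > 40000 nM. Compound 2 `Cc1cccc(-n2cc(CNC(=O)c3cccc4c3cnn4C(C)C)nn2)c1` carries a 3-methylphenyl. In this assay compound 2 likewise yields only a limit, > 40000 nM. Compound 3 `CC(C)n1ncc2c(C(=O)NCc3cn(-c4ccccc4F)nn3)cccc21` carries a 2-fluorophenyl. In this assay compound 3 also returns only a limit, > 40000 nM. Compound 3 therefore stands where every measured compound stands, at the limit of > 40000 nM in this assay, at which 3 of the 3 values shown sit, and the steps a step that the two limits leave unreadable from compound 1 to compound 2, a step that the two limits leave unreadable from compound 1 to compound 3 and a step that the two limits leave unreadable from compound 2 to compound 3 cannot be read in size or direction.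

Compound 4 `CCc1ccc(-n2cc(CNC(=O)c3cccc4c3cnn4C(C)C)nn2)cc1` is not yet measured. It differs from compound 3 by 4-ethylphenyl in place of 2-fluorophenyl on an aromatic nitrogen. Among the compounds with values here, the measured steps that bear on this change are the three aryl swaps on the same ring nitrogen, and each is unreadable between two limits, so no size of step and no direction can be drawn from them. Compound 4 is expected to remain at the limit as well, with an expected step of a number no higher from compound 3 to compound 4 (the limit leaves the size open). The estimate for compound 4 in this assay is 40000 nM, with a range from 15000 nM to 120000 nM.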

Compound 4, half-maximal inhibitory concentration: > 40000 nM
Compound 4 gave a limit, no number; the forecaster's own chance of this, stated with the estimate: 80%; the middle value sits exactly at the limit.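

In this assay compound 4 also gives only a limit, > 40000 nM and no number. Within the data shown here, no step from compound 4 to compound 1, compound 2 or compound 3 can be read in size or direction, because all four sit at one limit: the limit of > 40000 nM in this assay, at which 4 of the 4 values shown sit.

The compounds shown leave open whether any aryl group on this nitrogen gives a readable value in this assay at all, and how these four compounds rank.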